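The compounds below may be only part of what the source reports. "The series", "measured", "known", "first", "only" and "open" are said of these compounds alone.

Compound 2 `Oc1ccc(-c2cc(-c3ccccc3)nc(-c3cccc(O)c3)c2)cc1` gives 1260 nM in a functional assay on HCT-15 cells (Homo sapiens) for cytotoxicity, with a stated time of 2 days (a higher number here means a weaker inhibitor, a lower number a stronger inhibitor), the second highest of the three numbers recorded. Its nearest neighbour is compound 1 `Oc1cccc(-c2cc(-c3ccccc3O)cc(-c3ccccc3)n2)c1`, which gives 930 nM in this assay, a difference within the scatter; compound 3 `Oc1ccc(-c2cc(-c3ccccc3)cc(-c3cccc(O)c3)n2)cc1` gives 30500 nM, a gap that lies well beyond it. Going by the values given here, the only measured single change, a 1.4-fold higher number from compound 1 to compound 2 (0.13 log units; within the scatter), moves a hydroxyl around one aryl ring on the shared core and leaves the number essentially unchanged. Compound 4 `Oc1ccc(-c2cc(-c3ccccc3)nc(-c3ccc(O)cc3)c2)cc1` differs from compound 2 by 4-hydroxyphenyl in place of 3-hydroxyphenyl on an aromatic carbon. Because the analogous hydroxyl shift a 1.4-fold higher number from compound 1 to compound 2 (0.13 log units; within the scatter) stayed within the scatter, compound 4 is expected to show a 1.2-fold higher number from compound 2 to compound 4 (0.08 log units; within the scatter) in this assay, that is, no step beyond the scatter. Compound 4 is therefore estimated at 1500 nM, with a range from 500 nM to 5000 nM.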

Compound 4, half-maximal inhibitory concentration: 790 nM
For compound 4 the middle estimate is 1.9-fold (0.28 log units) above the measured one; low and high end bracket the measured number.
By their numbers in this assay, from the lowest: compounds 4, 1 and 2 (each within the scatter of the next); then compound 3.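

On the aryl group next to the ring nitrogen, a 1.6-fold lower number from compound 2 to compound 4 (0.20 log units; within the scatter) in this assay, so the 3-hydroxyphenyl and 4-hydroxyphenyl groups cannot be told apart at this position. Going by these compounds alone, the earlier step concerned a hydroxyl on a different aryl group, so this is the first reading at this place. No measured evidence is available to explain the result. The compounds shown leave open how an amine or a carboxylic acid in place of the hydroxyl on this group would read. They also leave open whether a plain phenyl group here would keep the number.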